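This account rests on a few compounds, and the source may have more. Where it says the series, first, only, none or still open, it means among the compounds named here.

Compound 1 `CCOC(=O)C1=C(C)N(c2ccccc2)C=CC1c1ccccc1` was tested in a functional assay, tested at 100 ug/mL (a lower number here means a stronger effect, a higher number a weaker effect of the compound at the concentration tested), and gave -13.8%. Its two measured relatives alter only the aromatic substituent: compound 2 `CCOC(=O)C1=C(C)N(c2ccc(C)cc2)C=CC1c1ccccc1` gives -20.7% in this assay, and compound 3 `CCOC(=O)C1=C(C)N(c2ccc(Br)cc2)C=CC1c1ccccc1` gives -14.8%. Of the three numbers that of compound 1 is nominally the highest, yet every step among them lies within the scatter: a number 1 percentage points lower from compound 1 to compound 3 (within the scatter) and a number 6.9 percentage points lower from compound 1 to compound 2 (within the scatter), with a number 5.9 percentage points higher from compound 2 to compound 3 (within the scatter) between the other two. The step to compound 4 `CC1=C(C(=O)OC(C)(C)C)C(c2ccccc2)C=CN1c1ccccc1` is of a different kind, (tert-butyl in place of ethyl on an oxygen next to a carbonyl group). Among the compounds with values here, no measured pair touches the ester, so nothing among the steps speaks directly to this change; what the three compounds do show is that the numbers stay close together whatever is varied so far. On that basis the estimated step is a number 0.2 percentage points lower from compound 1 to compound 4 (within the scatter), that is, no movement beyond the scatter. Compound 4 is therefore expected to give about -14% in this assay, within a range from -32% to 4%.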

Compound 4, a percentage reported as activity, at one concentration (the size of the read-out at that concentration, not a potency): -23.1%
Estimate against measurement, compound 4: 9.1 percentage points above; measured number inside the range.
By their numbers in this assay, from the lowest: compounds 4, 2, 3 and 1 (each within the scatter of the next).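

The ester now has a measured step of its own: with tert-butyl in place of ethyl on an oxygen next to a carbonyl group, this assay gives a number 9.3 percentage points lower from compound 1 to compound 4 (within the scatter). A change away from the aromatic substituent therefore also leaves the read-out within the scatter, so this position, like the aromatic one, shows no clear response so far. Nothing available gives a reason for the size of this step.

On these data alone, this position rests on one step only, so it remains open whether the ester is truly insensitive or whether a larger change would move the number beyond the scatter. As far as these compounds go, a free carboxylic acid, an amide or a longer chain on the oxygen could each test that, and their effect remains unknown.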